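Side-chain change from compound 2 to compound 3

The source may hold more compounds than are shown below. What is called first, only, known or untested is meant among the compounds shown, and "the series" means these compounds.

In a functional assay on MCF7 cells (Homo sapiens) for cytotoxicity, read by MTT assay, with a stated time of 72 h (a lower number here means a stronger inhibitor, a higher number a weaker inhibitor), compound 1 `O=C1c2c[n+]([O-])c3ccccc3c2C(=O)c2c1c1ccccc1n2CCN1CCCC1` gives 320 nM. Compound 2 `CCCCN1CCN(CCCCn2c3c(c4ccccc42)C(=O)c2c[n+]([O-])c4ccccc4c2C3=O)CC1` gives 6900 nM, the higher of the two numbers. Among the measured compounds shown here, the only measured step, a 22-fold higher number from compound 1 to compound 2 (1.33 log units; beyond the scatter), is large, with 2-(4-butylpiperazin-1-yl)ethyl in place of pyrrolidin-1-yl. Compound 3 `CN1CCN(CCCCCCn2c3c(c4ccccc42)C(=O)c2c[n+]([O-])c4ccccc4c2C3=O)CC1` carries 2-(4-methylpiperazin-1-yl)ethyl in place of 4-butylpiperazin-1-yl on a saturated chain carbon, four bonds along the chain from an aromatic nitrogen, four bonds along the chain from an aromatic nitrogen. That measured step is a different change on the same chain, so it offers only weak guidance. A small expected move towards a lower number reads a 2.0-fold lower number from compound 2 to compound 3 (0.29 log units; within the scatter). The estimate in this assay for compound 3 is 3500 nM, with an expected range of 900 nM to 12000 nM.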

Compound 3, half-maximal inhibitory concentration: 400 nM
The estimate for compound 3 lay 8.8-fold (0.94 log units) above the measured number, and the stated range ends above it.
By their numbers in this assay, from the lowest: compounds 1 and 3 (each within the scatter of the next); then compound 2.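

On the saturated chain, a piperazine at the chain end does not by itself carry the high number: 2-(4-methylpiperazin-1-yl)ethyl in place of 4-butylpiperazin-1-yl gives a 17-fold lower number from compound 2 to compound 3 (1.24 log units; beyond the scatter) at the position four bonds along the chain from an aromatic nitrogen. In this assay there is a 1.3-fold higher number from compound 1 to compound 3 (0.10 log units; within the scatter) with 4-(4-methylpiperazin-1-yl)butyl in place of pyrrolidin-1-yl, so these two side chains cannot be told apart. Nothing measured here gives a cause for either step.

The step from compound 2 joins a methyl for butyl swap on the piperazine to a longer chain, and the two changes remain unseparated. A 4-methylpiperazin-1-yl group on the shorter chain of compound 2, or a morpholine at the chain end, would bear on this.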